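From 3-fluorobenzyl to 4-methylbenzyl on the amide nitrogen

A few compounds are considered here, and "the series" means these few. Any claim that something is new, unique, unknown or untested is made for them only; others in the source may bear on it.

In a functional assay on HeLa cells (Homo sapiens) for inhibition, read by MTT assay, with a stated time of 48 h (on this read-out higher numbers stand for weaker inhibition and lower numbers for stronger inhibition), compound 1 (`COc1ccc2c(=O)c(/C=C/C(=O)Nc3cccc(C)c3)coc2c1`) gives > 100000 nM as a limit of the assay and not a number. Compound 3 (`COc1ccc(NC(=O)/C=C/c2coc3cc(O)ccc3c2=O)cc1`) gives > 100000 nM in this assay and this too is a limit. Among the measured compounds shown here, compound 2 (`COc1ccc2c(=O)c(/C=C/C(=O)NCc3cccc(F)c3)coc2c1`) gives 17600 nM and stands as the only compound here with an actual number. The evidence is thin (the limit of > 100000 nM in this assay, at which 2 of the 3 values shown sit) and offers no ranking beyond that.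

Compound 4 (`COc1ccc2c(=O)c(/C=C/C(=O)NCc3ccc(C)cc3)coc2c1`) has not yet been measured. It differs from compound 2 by 4-methylphenyl in place of 3-fluorophenyl on a saturated chain carbon bound to an amide-type nitrogen so that 4-methylphenyl stands in place of 3-fluorophenyl on a saturated chain carbon bound to an amide-type nitrogen.

For the measured compounds named here, only one measured step bears on this change. With 3-fluorobenzyl in place of 3-methylphenyl on an amide-type nitrogen, the data show an at least 5.6-fold lower number from compound 1 to compound 2 (0.75 log units; beyond the scatter) and that lies beyond the scatter. Since compound 2 gives 17600 nM with that saturated chain carbon in place and compound 4 keeps it, an actual number is expected for compound 4 as well. The estimated step is a 1.5-fold higher number from compound 2 to compound 4 (0.17 log units; within the scatter) in this assay which is expected to stay within the scatter, with only a slight lean toward weaker inhibition. For compound 4 the estimate is 26000 nM with an expected range from 9000 nM to 80000 nM as the likely span.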

Compound 4, half-maximal inhibitory concentration: > 100000 nM
Compound 4: no number, only a limit; the forecaster's own chance of this, stated with the estimate: 20%; middle value at least 3.8-fold (0.58 log units) away from the limit.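

Exchanging 3-fluorobenzyl for 4-methylbenzyl on the amide nitrogen gives an at least 5.6-fold higher number from compound 2 to compound 4 (0.75 log units; beyond the scatter) in this assay, so the saturated chain carbon bound to the amide-type nitrogen does not by itself secure a measurable number. The earlier step at this nitrogen changed the chain carbon and the ring substituent together, whereas here the chain carbon stays and only 3-fluorophenyl gives way to 4-methylphenyl, which shows that the ring substituent alone can move the value beyond the scatter. Compound 4 gives > 100000 nM, a limit of the assay and not a number, and the step from compound 1 to compound 4 cannot be read, so the comparison stops there: the limit of > 100000 nM in this assay, at which 3 of the 4 values shown sit.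

The compounds shown do not separate the two parts of this change, the loss of the 3-fluoro group and the arrival of the 4-methyl group, and a 3-methylbenzyl or 4-fluorobenzyl group on the same nitrogen would tell them apart. They also leave open how a longer chain such as 2-phenylethyl, or a ring bearing an amine such as 4-dimethylaminobenzyl, would read in this assay.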